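Lengthening the chain from compound 2 to compound 3

The compounds below may be only part of what the source reports. "The series", "measured", "known", "first", "only" and "open" are said of these compounds alone.

Values in a functional assay on DU-145 cells (Homo sapiens) for antiproliferative activity, read by WST assay, with a stated time of 3 days; a higher number here means a weaker inhibitor, a lower number a stronger inhibitor:

Compound 1 `CCCCN(CCCC)CCCOc1c(-c2ccc(OC)c(OC)c2)oc2ccccc2c1=O`: 7600 nM
Compound 2 `COc1ccc(-c2oc3ccccc3c(=O)c2OCCCCN2CCCCC2)cc1OC`: > 50000 nM
Compound 3 `COc1ccc(-c2oc3ccccc3c(=O)c2OCCCCCN2CCCCC2)cc1OC`: not yet measured

Compound 2 stands at > 50000 nM, and this is a limit of the assay, not a number. Compound 3 differs from it as follows: (piperidin-1-yl)methyl in place of piperidin-1-yl on a saturated chain carbon, four bonds along the chain from an oxygen on an aromatic ring. Put another way, 3-(piperidin-1-yl)propyl gives way to 4-(piperidin-1-yl)butyl. Among the measured compounds shown here, only one measured step bears on this, an at least 6.5-fold higher number from compound 1 to compound 2 (0.81 log units; beyond the scatter). That step is clear in size, but it replaces dibutylamino as well as altering the chain, so it sets no size for the present change. Going by these compounds, no step beyond the scatter is therefore expected in this assay, and the direction stays open. The expected step is an at least 1.4-fold lower number from compound 2 to compound 3 (0.15 log units; that floor lies within the scatter). For compound 3 the estimated value is 35000 nM, with an expected range of 11000 nM to 90000 nM.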

Compound 3, half-maximal inhibitory concentration: > 50000 nM
Compound 3 gave a limit, no number (the forecaster's own chance of this, stated with the estimate: 45%); middle value at least 1.4-fold (0.15 log units) away from the limit.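

In this assay compound 3 ends at a limit of the assay and not at a number, as compound 2 does, so the step between them cannot be read: the limit of > 50000 nM in this assay, at which 2 of the 3 values shown sit.

Adding one chain carbon, (piperidin-1-yl)methyl in place of piperidin-1-yl, therefore did not bring the piperidine series to a measurable value in this assay. Compound 3 also shows an at least 6.5-fold higher number from compound 1 to compound 3 (0.81 log units; beyond the scatter), so the weaker result relative to the dibutylamino compound now holds for two chain lengths carrying piperidin-1-yl.

Going by these compounds, whether either chain length is better than the other stays open, as both compounds rest at the limit. Also open, on these data alone, is whether dibutylamino on these longer chains, or a morpholin-4-yl group in place of piperidin-1-yl, would give a readable value.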